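Compound 2 to compound 3: 4-chlorophenyl swap

This account rests on a few compounds, and the source may have more. Where it says the series, first, only, none or still open, it means among the compounds named here.

In a functional assay on ECa-109 cells (Homo sapiens) for cytotoxicity, read by MTT assay, with a stated time of 48 h (on this read-out lower numbers stand for stronger inhibition and higher numbers for weaker inhibition), compound 1 (`COc1ccc(-c2c(-c3cc(OC)c(OC)c(OC)c3)noc2NC(C)=O)cc1`) gives 10800 nM and compound 2 (`COc1ccc(-c2c(-c3cc(OC)c(OC)c(OC)c3)noc2NC(C)=O)cc1OC`) gives 17700 nM. Among the measured compounds shown here, these two values lie within the scatter of each other, so compound 2 stands level with compound 1 on the numbers so far.

Compound 3 (`COc1cc(-c2noc(NC(C)=O)c2-c2ccc(Cl)cc2)cc(OC)c1OC`) is still unmeasured. Its difference from compound 2 is 4-chlorophenyl in place of 3,4-dimethoxyphenyl on an aromatic carbon. For the measured compounds named here, the only measured step bearing on this is a 1.6-fold higher number from compound 1 to compound 2 (0.21 log units; within the scatter), with methoxy in place of hydrogen on an aromatic carbon, and it stays within the scatter. Going by the values given here, no measured compound carries 4-chlorophenyl, so the range must stay wide. No step beyond the scatter is expected in this assay. The estimated step is a 1.5-fold lower number from compound 2 to compound 3 (0.17 log units; within the scatter). For compound 3 the expected value is 12000 nM, with an estimated range of 4000 nM to 35000 nM.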

Compound 3, half-maximal inhibitory concentration: 9530 nM
The estimate for compound 3 lay 1.3-fold (0.10 log units) above the measured number, within the range that was stated.
By their numbers in this assay, from the lowest: compounds 3, 1 and 2 (each within the scatter of the next).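

On the aromatic carbon next to the ring atom that bears an acetamido group, 4-chlorophenyl in place of 3,4-dimethoxyphenyl gives a 1.9-fold lower number from compound 2 to compound 3 (0.27 log units; within the scatter) in this assay, so even replacing the whole aryl group with one carrying no oxygen produces no step beyond the scatter. Chloro in place of methoxy on an aromatic carbon gives a 1.1-fold lower number from compound 1 to compound 3 (0.05 log units; within the scatter), which leaves compounds 1, 2 and 3 level whether this phenyl ring carries methoxy, 3,4-dimethoxy or chloro. No evidence is available that bears on this result.

As far as these compounds go, whether an amine or a carboxylic acid on this phenyl ring would give a step beyond the scatter remains open, as does the effect of a longer chain in place of the acetamido group's methyl. With all three values within the scatter of each other, the compounds shown do not reveal which parts of the shared core the cytotoxicity depends on.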